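The source may hold more compounds than are shown below. What is called first, only, known or untested is meant among the compounds shown, and "the series" means these compounds.

compound 1 `COc1ccc(C(=O)c2ccc(OC)c3c2C=CC(C)(C)O3)c(NC(=O)CN(C)C)c1`: 3990 nM
compound 2 `COc1ccc(C(=O)c2ccc3c(c2)C=CC(C)(C)O3)c(NC(=O)CN(C)C)c1`: 1020 nM
compound 3 `COc1ccc(C(=O)c2cc(OC)c(OC)c(OC)c2)c(NC(=O)CO)c1`: 100 nM

In a functional assay on A2780 cells (Homo sapiens) for antiproliferative activity, read by MTT assay, with a stated time of 48 h (a higher number here means a weaker inhibitor, a lower number a stronger inhibitor), compound 3 has the lowest number of the three, and its gaps to both compound 2 and compound 1 lie beyond the usual scatter of repeated measurements. No two of these measured compounds differ in only one place, so the data offer no direct measure of a single change. Compound 4 `CNCC(=O)Nc1cc(OC)ccc1C(=O)c1cc(OC)c(OC)c(OC)c1` keeps the rest of compound 3 but has methylamino in place of hydroxy on a saturated chain carbon bound to a carbonyl carbon. Within the data shown here, this swap has no measured example here. The higher numbers of compound 2, at 1020 nM, and compound 1, at 3990 nM, give only a weak hint, since their cores also differ from that of compound 3. A small rise in the number is therefore expected in this assay, perhaps none beyond the scatter. The expected change is a step of a 1.7-fold higher number from compound 3 to compound 4 (0.23 log units; within the scatter). The estimated value for compound 4 is 170 nM, with an expected range from 40 nM to 800 nM.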

Compound 4, half-maximal inhibitory concentration: 580 nM
For compound 4 the middle estimate is 3.4-fold (0.53 log units) below the measured one; the range from low to high includes it.
By their numbers in this assay, from the lowest: compound 3; then compounds 4 and 2 (each within the scatter of the next); then compound 1.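

With the rest of compound 3 kept, methylamino in place of hydroxy on a saturated chain carbon bound to a carbonyl carbon gives a 5.8-fold higher number from compound 3 to compound 4 (0.76 log units; beyond the scatter) in this assay and provides the first direct reading of a single change among these compounds. The step lies beyond the scatter, so activity in this series responds to the group at this position, even though hydroxy and methylamino have the same counts of hydrogen-bond donors and acceptors. Nothing measured here accounts for the rise in the number.

On these data alone, how an unsubstituted amino group, a carboxylic acid or a longer chain would fare at this place remains open. Compounds 1 and 2 carry a dimethylamino group there, but their cores also differ from that of compound 4, so the steps to them cannot be read.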